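Amino Substitution on Two Related Nucleoside Cores

The source may report more compounds than this note shows. Statements on the series, on what has been measured and on what is new or still open speak of the compounds shown alone.

Compound 1 `COc1ncnc2c1c(-c1ccsc1)cn2[C@@H]1O[C@H](CO)[C@@H](O)[C@H]1O` gives 7640 nM in a functional assay on CEM-DNR-bulk cells (Homo sapiens), read by MTT assay, with a stated time of 72 h; a higher number here means a weaker inhibitor, a lower number a stronger inhibitor.
Compound 2 `COc1nc(N)nc2c1c(-c1ccsc1)cn2[C@@H]1O[C@H](CO)[C@@H](O)[C@H]1O` gives > 20000 nM in this assay, which is a limit of the assay and not a number.
Compound 3 `O=c1[nH]cnc2c1c(-c1ccco1)cn2[C@@H]1O[C@H](CO)[C@@H](O)[C@H]1O` gives > 20000 nM in this assay, again a limit of the assay.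

The change from compound 1 to compound 2 is amino in place of hydrogen on an aromatic carbon. In this assay it produces an at least 2.6-fold higher number from compound 1 to compound 2 (0.41 log units; beyond the scatter), and the size of that step is known only as a bound because compound 2 sits at the limit of > 20000 nM in this assay, at which 2 of the 3 values shown sit. The difference between the core of compound 1 and the core of compound 3 is not broken down here.

Compound 4 `Nc1nc2c(c(-c3ccco3)cn2[C@@H]2O[C@H](CO)[C@@H](O)[C@H]2O)c(=O)[nH]1` has not been measured. It differs from compound 3 by amino in place of hydrogen on an aromatic carbon. This is the same kind of change as that from compound 1 to compound 2, though the surroundings differ: in compound 3 the site is meta to a group of 1 heavy atom, whereas in compound 1 it is meta to a methoxy group (2 heavy atoms).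

Compound 3 already stands at a limit. The same change weakened compound 1 by an at least 2.6-fold higher number from compound 1 to compound 2 (0.41 log units; beyond the scatter). Compound 4 is therefore expected to give 40000 nM, within an estimated range from 15000 nM to 150000 nM. The expected step is a step that the limit leaves unreadable from compound 3 to compound 4, and it will most likely again be reported only as a limit.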

Compound 4, half-maximal inhibitory concentration: > 20000 nM
Compound 4 was reported as a limit; the forecaster's own chance of this, stated with the estimate: 90%; the middle value does not contradict the limit.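

Compound 4 gives > 20000 nM in this assay, which is a limit of the assay and not a number. Compound 3 stands at a limit too, so no step from it to compound 4 can be read: the limit of > 20000 nM in this assay, at which 3 of the 4 values shown sit.

The compounds shown leave open whether amino in place of hydrogen on an aromatic carbon acts on the core of compound 3 as it does on the core of compound 1.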